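Replacing a benzyl group with a sulfonyl on the piperidine nitrogen

This account rests on a few compounds, and the source may have more. Where it says the series, first, only, none or still open, it means among the compounds named here.

Measured so far:
- compound 1, `COc1ccc2nccc(C3CN(C4CCN(Cc5cc6ccccc6[nH]5)CC4)C(=O)O3)c2c1`: 25.1 nM
- compound 2, `COc1ccc2nccc(C3CN(C4CCN(Cc5cccc(Cl)c5)CC4)C(=O)O3)c2c1`: 6310 nM
- compound 3, `COc1ccc(CN2CCC(N3CC(c4ccnc5ccc(OC)cc45)OC3=O)CC2)cc1`: 1260 nM

All three compounds share one core and differ only in the group carried on the ring nitrogen. In an in vitro functional assay on RBL cells for antagonist activity at C-C chemokine receptor type 8 (Homo sapiens), read by FLIPR and calcium flux (on this read-out lower numbers stand for stronger inhibition and higher numbers for weaker inhibition), compound 3 gives 1260 nM, the second highest of the three numbers: compound 1, which carries the 1H-indol-2-yl group, sits far lower, as a 50-fold higher number from compound 1 to compound 3 (1.70 log units; beyond the scatter) shows, while compound 2 sits above it, as a 5.0-fold lower number from compound 2 to compound 3 (0.70 log units; beyond the scatter) shows.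

Compound 4, `COc1ccc2nccc(C3CN(C4CCN(S(=O)(=O)c5ccc(Cl)c(Cl)c5)CC4)C(=O)O3)c2c1`, changes this position once more: (3,4-dichlorophenyl)sulfonyl in place of 4-methoxybenzyl on an amine nitrogen in a ring. Going by the values given here, no measured step involves a sulfonyl group, so the steps to hand only show how much this position matters. The steps of a 250-fold higher number from compound 1 to compound 2 (2.40 log units; beyond the scatter) and a 50-fold higher number from compound 1 to compound 3 (1.70 log units; beyond the scatter) were large, and a 5.0-fold lower number from compound 2 to compound 3 (0.70 log units; beyond the scatter) was modest, so a change here can move the number a great deal in either direction. For compound 4 an unchanged number is therefore expected, with a wide range: a 1.1-fold lower number from compound 3 to compound 4 (0.02 log units; within the scatter), giving an estimate of 1200 nM (from 100 nM to 12000 nM).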

Compound 4, half-maximal inhibitory concentration: < 50200 nM
Compound 4 ended at the assay's limit; the forecaster's own chance of this, stated with the estimate: 20%; the middle value does not contradict the limit.
By their numbers in this assay, from the lowest: compound 1; then compound 3; then compound 2.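

In this assay compound 4 gives < 50200 nM, which is a limit of the assay and not a number. Going by these compounds alone, no step from compound 1, compound 2 or compound 3 to compound 4 can be read. From the compounds shown here alone, how the (3,4-dichlorophenyl)sulfonyl group compares with the other three groups on the ring nitrogen stays open.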